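The compounds below may be only part of what the source reports. "The series", "measured", "known", "first", "only" and "open" are said of these compounds alone.

Measured in an ADME assay on MRC5 cells (Homo sapiens) for cytotoxicity, read by fluorescence and resazurin assay, with a stated time of 3 days; a higher number here means a weaker inhibitor, a lower number a stronger inhibitor:
Compound 1 `Cc1cn(C2CCN(Cc3cccc(Oc4cc(F)cc(F)c4)c3)CC2)c(=O)[nH]c1=O`: > 64000 nM, a limit of the assay
Compound 2 `Cc1cn(C2CCN(Cc3cccc(Oc4ccc(Cl)c(Cl)c4)c3)CC2)c(=O)[nH]c1=O`: 6100 nM

For the measured compounds named here, compound 2 holds the only true number in this assay, as the other result is the limit of > 64000 nM in this assay, at which 1 of the 2 values shown sits. Compound 3 `Cc1cn(C2CCN(Cc3cccc(OC4CCCCC4)c3)CC2)c(=O)[nH]c1=O` carries cyclohexyl in place of 3,4-dichlorophenyl on an oxygen on an aromatic ring. One measured change at this place bears on it, an at least 10-fold lower number from compound 1 to compound 2 (1.02 log units; beyond the scatter), a large step. It suggests that this group can matter, though it does not include cyclohexyl, so the direction remains uncertain. A moderate rise is expected, a 2.6-fold higher number from compound 2 to compound 3 (0.42 log units; beyond the scatter), smaller than that measured step. Compound 3 is estimated at 16000 nM, within a range from 5000 nM to 64000 nM.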

Compound 3, half-maximal inhibitory concentration: 23600 nM
Compound 3: the middle estimate sits 1.5-fold (0.17 log units) below what was measured; measured number inside the range.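

In this assay, cyclohexyl in place of 3,4-dichlorophenyl gives a 3.9-fold higher number from compound 2 to compound 3 (0.59 log units; beyond the scatter), so a measurable number at this position does not depend on an aromatic ring on the oxygen. Cyclohexyl in place of 3,5-difluorophenyl gives an at least 2.7-fold lower number from compound 1 to compound 3 (0.43 log units; beyond the scatter), which places compound 3 between the two aryl ethers. That second step has no upper end because compound 1 sits at a limit: the limit of > 64000 nM in this assay, at which 1 of the 3 values shown sits.

Compound 3 loses the chlorines and the aromatic ring together, so their shares in the step remain unseparated. On these data alone, whether a plain phenyl, or a cyclohexyl bearing an amine or a carboxylic acid, would move the number further also remains open.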